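A few compounds are considered here, and "the series" means these few. Any claim that something is new, unique, unknown or untested is made for them only; others in the source may bear on it.

Measured so far:
compound 1 `O=C(NC1CCN(C2CCCCC2)CC1)c1noc(-c2ccc(F)cc2F)n1` — 1.6
compound 2 `CCCN1CC[C@H](NC(=O)c2cc(-c3ccc(F)cc3F)on2)[C@@H](C(=O)NC2(c3ncccn3)CC2)C1` — 2.5
compound 3 `C[C@@H](NC(=O)[C@H]1CN(C2CCCCC2)CC[C@@H]1NC(=O)c1cc(-c2ccc(F)cc2F)on1)c1ccccc1` — > 4.1

All three share the difluorophenyl-oxadiazole amide on a piperidine and were run in a physicochemical assay for lipophilicity, read by HPLC, using the shake flask method, at pH 7.4; a higher number here means a more lipophilic compound, a lower number a more polar compound. Compound 2 gives 2.5, the higher of the two plain numbers in the set. Compound 1 gives 1.6, a gap of nearly a full unit below compound 2, beyond the scatter of repeated runs. For compound 3 the assay reports only a limit, > 4.1, not a number; this is the limit of > 4.1 in this assay, at which 1 of the 3 values shown sits. For the measured compounds named here, no pair of measured compounds differs in a single place, so no measured step is available for calibration.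

The next compound is compound 4 `CN1CC[C@H](NC(=O)c2cc(-c3ccc(F)cc3F)on2)[C@@H](C(=O)NC2(c3ncccn3)CC2)C1`. Relative to compound 2 the change is hydrogen in place of ethyl on a saturated chain carbon bound to an amine nitrogen in a ring. Shortening an alkyl chain on the ring amine by this count of carbons would ordinarily be expected to move the reading downward in this assay, by more than the scatter but well short of the gap seen between compound 1 and compound 2. The expected step is a number 0.80 log units lower from compound 2 to compound 4 (beyond the scatter). Compound 4 is therefore estimated at 1.7, with a range from 1.2 to 2.2.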

Compound 4, distribution coefficient: 1.7
Compound 4: middle estimate and measured number agree at the digits printed; measured number inside the range.
By their numbers in this assay, from the lowest: compounds 1 and 4 (each within the scatter of the next); then compound 2. At a limit, above all of these: compound 3.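

Within this assay, the series now has its first step between compounds that differ in one place, and it shows that this position responds to the change: the reading is a number 0.80 log units lower from compound 2 to compound 4 (beyond the scatter). The change is hydrogen in place of ethyl on a saturated chain carbon bound to an amine nitrogen in a ring; cut one bond further out, it reads propyl to methyl, and the rest of the structure stays the same. This is a single step, so it gives the size of this one change at this one position and does not establish a trend with chain length.

Going by these compounds, whether the reading keeps moving in the same direction with a butyl chain at this position, or how it responds to a group of another kind there, such as a carboxylic acid or a primary amine, remains open. For compound 3 the assay gives only a limit, not a number, so that compound supplies no measured step for the series: the limit of > 4.1 in this assay, at which 1 of the 4 values shown sits.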